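Acetyl in Place of the Acid Chain at the Tail

A few compounds are considered here, and "the series" means these few. Any claim that something is new, unique, unknown or untested is made for them only; others in the source may bear on it.

Compound 1, `CC(=O)Nc1ccc(CNC(=O)c2ccc(C(C)(C)C)cc2)cc1`, gives 2900 nM in an assay on HeLa cells with Bile acid receptor (Homo sapiens) as the target, read by a luciferase reporter, with a stated time of 24 h; a higher number here means that more compound is needed for the effect, a lower number that less compound is needed. Compound 2, `CC(C)(C)c1ccc(C(=O)NCc2ccc(S(C)(=O)=O)cc2)cc1`, gives 3800 nM in this assay. Compound 3, `CC(C)(C)c1ccc(C(=O)NCc2ccc(CCC(=O)O)cc2)cc1`, gives 350 nM in this assay.

Compound 3 stands lowest of the three numbers. The change an 8.3-fold lower number from compound 1 to compound 3 (0.92 log units; beyond the scatter) and the change an 11-fold lower number from compound 2 to compound 3 (1.04 log units; beyond the scatter) both lie beyond the scatter, while a 1.3-fold higher number from compound 1 to compound 2 (0.12 log units; within the scatter) does not, so the two groups that carry no net charge sit together and the 2-carboxyethyl group stands apart.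

Compound 4, `CC(=O)c1ccc(CNC(=O)c2ccc(C(C)(C)C)cc2)cc1`, is the next step from compound 3: acetyl in place of 2-carboxyethyl on an aromatic carbon. The acetyl group, like the acetamido of compound 1 and the methylsulfonyl of compound 2, brings no hydrogen-bond donor and no net charge, whereas the 2-carboxyethyl group that leaves brought one donor. The two steps into compound 3 are the ones that bear on this move, and they were modest to large. Compound 4 is therefore expected to return toward the numbers of compounds 1 and 2, that is an 8.6-fold higher number from compound 3 to compound 4 (0.93 log units; beyond the scatter) in this assay. For compound 4 the estimate in this assay is 3000 nM, with a range from 1000 nM to 10000 nM.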

Compound 4, half-maximal effective concentration: 100 nM
For compound 4 the middle estimate is 30-fold (1.48 log units) above the measured one, and the stated range ends above it.
By their numbers in this assay, from the lowest: compound 4; then compound 3; then compounds 1 and 2 (each within the scatter of the next).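

In this assay the acetyl group on this aromatic carbon goes lower than the 2-carboxyethyl group that it replaces (a 3.5-fold lower number from compound 3 to compound 4 (0.54 log units; beyond the scatter)), so the acid chain and its hydrogen-bond donor are not required for a low number at this position. The acetamido group also holds a carbonyl, yet acetyl stands far apart from it (a 29-fold lower number from compound 1 to compound 4 (1.46 log units; beyond the scatter)) and from methylsulfonyl (a 38-fold lower number from compound 2 to compound 4 (1.58 log units; beyond the scatter)), so neither a carbonyl alone nor the absence of the acid chain accounts for the low number of compound 4. Nothing shown here gives a measured reason for these steps.

Going by these compounds, whether the low number is particular to acetyl stays open, since a longer ketone chain or a methyl ester at this place could test it. On these data alone, how a bare carboxylic acid or an amine on the same aromatic carbon would stand in this assay also remains open.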